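This account rests on a few compounds, and the source may have more. Where it says the series, first, only, none or still open, it means among the compounds named here.

Three compounds built on a shared core differ in how that core is linked to their hydroxycarbamoyl group. In a functional assay on HEL cells (Homo sapiens) for inhibition, read by MTT assay, with a stated time of 48 h (on this read-out lower numbers stand for stronger inhibition and higher numbers for weaker inhibition), compound 1 `O=C(CCCCOc1no[n+]([O-])c1S(=O)(=O)c1ccccc1)NO` gives 1030 nM and compound 3 `O=C(NO)c1ccc(Oc2no[n+]([O-])c2S(=O)(=O)c2ccccc2)cc1` gives 920 nM and these two numbers lie within the usual scatter of repeated measurements. Compound 3 therefore stands level with compound 1, and neither can be called the better of the pair. Compound 2 `O=C(/C=C/COc1no[n+]([O-])c1S(=O)(=O)c1ccccc1)NO` adds nothing to the comparison, since its entry reads "not determined" (no result reported) and gives no number.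

The next step starts from compound 3. Compound 4 `COc1cc(C(=O)NO)ccc1Oc1no[n+]([O-])c1S(=O)(=O)c1ccccc1` carries methoxy in place of hydrogen on an aromatic carbon, ortho to a large group and meta to a hydroxycarbamoyl group, and the change counts as methoxy in place of hydrogen on an aromatic carbon in full.

No measured pair among these compounds shows what such a swap does, so any forecast here is rough. With nothing to set a direction, the expectation in this assay is no shift beyond the scatter, starting from the 920 nM of compound 3. The expected change is a 1.2-fold lower number from compound 3 to compound 4 (0.06 log units; within the scatter) and it should be read as a small one. For compound 4 the estimated value is 800 nM with an expected range from 300 nM to 2200 nM in a repeat measurement.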

Compound 4, half-maximal inhibitory concentration: 5550 nM
For compound 4 the middle estimate is 6.9-fold (0.84 log units) below the measured one; measured number above the stated range.
By their numbers in this assay, from the lowest: compounds 3 and 1 (each within the scatter of the next); then compound 4.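

In this assay, putting methoxy in place of hydrogen on the aromatic carbon ortho to a large group and meta to a hydroxycarbamoyl group gives a 6.0-fold higher number from compound 3 to compound 4 (0.78 log units; beyond the scatter) and so means weaker inhibition. Among these compounds, this is the first measured pair in the set that differs in one place, and it shows that the ring of compound 3 does not accept every small addition without consequence: a methoxy group at this position moves the result beyond the usual scatter, by a modest step. The data at hand hold no measurement that accounts for this loss.

A single swap cannot separate the effect of methoxy itself from that of any added group on this carbon, and a fluorine atom, a methyl group or a hydroxyl group at the same place would help to make that distinction. Going by these compounds, it also remains open whether methoxy on a different aromatic carbon of this ring would weaken inhibition in the same way, or whether the step seen here belongs to this position alone.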